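Cell tolerance when azepan-1-yl replaces 2-methylpiperidin-1-yl

A few compounds are considered here, and "the series" means these few. Any claim that something is new, unique, unknown or untested is made for them only; others in the source may bear on it.

In an ADME assay on MT4 cells (Homo sapiens) for cytotoxicity, read by MTT assay, with a stated time of 4 days (a higher number here means that more compound is tolerated, a lower number that less compound is tolerated), compound 1 `Cc1c(Cc2c(F)cccc2F)nc(N(C)c2ccccc2)[nH]c1=O` gives > 73000 nM as its result, which is a limit and not a number. Compound 2 `Cc1c(Cc2c(F)cccc2F)nc(N2CCCC2)[nH]c1=O` shows > 82000 nM in this assay and this too is a limit. Only compound 3 `Cc1c(Cc2c(F)cccc2F)nc(N2CCCCC2C)[nH]c1=O` has a true number, with 75000 nM as its result, so it is the one firm reference point among the three.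

The next compound, compound 4 `Cc1c(Cc2c(F)cccc2F)nc(N2CCCCCC2)[nH]c1=O`, holds the same atoms joined differently, with azepan-1-yl in place of 2-methylpiperidin-1-yl on an aromatic carbon. The ring stays attached at the same place, but it grows from six-membered to seven-membered and loses its methyl branch.

The best guide is the earlier swap at that place, from pyrrolidin-1-yl to 2-methylpiperidin-1-yl, which gave an at least 1.0-fold lower number from compound 2 to compound 3 (0.03 log units; that floor lies within the scatter) in this assay and shows no change that can be told from the scatter. Neither a step that the two limits leave unreadable from compound 1 to compound 2 nor a step that the limit leaves unreadable from compound 1 to compound 3 offers a size to work with. No step beyond the scatter, in either direction, is therefore expected in this assay for the new swap. The estimate amounts to a 1.1-fold lower number from compound 3 to compound 4 (0.03 log units; within the scatter) as the expected step. For compound 4 the estimated value is 70000 nM with an expected range from 30000 nM to 120000 nM around it.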

Compound 4, half-maximal cytotoxic concentration: > 75000 nM
Compound 4: a limit, no number; the forecaster's own chance of this, stated with the estimate: 50%; middle value at least 1.0-fold (0.02 log units) away from the limit.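

In this assay, the change to azepan-1-yl gives a number no lower from compound 3 to compound 4 (the limit leaves the size open). At this place on the shared core, then, enlarging the ring to seven members and removing the methyl branch brings no loss of cell tolerance compared with the 2-methylpiperidin-1-yl group. Compound 4 gives a limit and not a number, so how large the step is stays open, and its steps from the two other compounds with limits cannot be read: the limit of > 75000 nM in this assay, at which 1 of the 4 values shown sits.

The compounds shown leave open whether any group at this place lowers cell tolerance clearly, as all the groups here are simple amines without a second hetero atom in a ring. Morpholin-4-yl or piperazin-1-yl, each of which puts a second hetero atom into a six-membered ring, would test that question in this assay.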